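The source may report more compounds than this note shows. Statements on the series, on what has been measured and on what is new or still open speak of the compounds shown alone.

Of the compounds shown here, two have been measured so far. Compound 1 `COc1ccc(-c2cc(/C=C/C(=O)c3ccc(N)cc3)[nH]n2)cc1` gives 1900 nM in a functional assay on UACC-257 cells (Homo sapiens) for inhibition, read by sulforhodamine B assay, with a stated time of 48 h; a higher number here means a weaker inhibitor of growth, a lower number a stronger inhibitor of growth. Compound 2 `COc1cc(-c2cc(/C=C/C(=O)c3ccc(Cl)c(Cl)c3)[nH]n2)cc(OC)c1OC` gives 16300 nM in the same assay, the higher of the two numbers, and the gap to compound 1 lies beyond the usual scatter. Compound 3 `COc1ccc(C(=O)/C=C/c2cc(-c3cc(OC)c(OC)c(OC)c3)n[nH]2)cc1` is not yet measured; it differs from compound 2 by 4-methoxyphenyl in place of 3,4-dichlorophenyl on a carbonyl carbon. Among the measured compounds shown here, no measured pair shows this change on its own, so its size is uncertain; compound 3 is expected to give a somewhat lower number than compound 2, a step of a 2.7-fold lower number from compound 2 to compound 3 (0.43 log units; beyond the scatter), with an estimate of 6000 nM and a range from 1500 nM to 25000 nM.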

Compound 3, concentration for 50% growth inhibition: 1750 nM
The estimate for compound 3 lay 3.4-fold (0.54 log units) above the measured number; the measured number falls inside the stated range.
By their numbers in this assay, from the lowest: compounds 3 and 1 (each within the scatter of the next); then compound 2.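

Among the compounds shown here, on a carbonyl carbon, in this assay, 4-methoxyphenyl in place of 3,4-dichlorophenyl gives a 9.3-fold lower number from compound 2 to compound 3 (0.97 log units; beyond the scatter) and is the first measured step at this position. Both groups count the same number of heavy atoms and carry one six-membered aromatic ring, so the group on that ring can move growth inhibition well beyond the scatter. Nothing measured here explains this step.

From the compounds shown here alone, it remains open whether the step follows from gaining the methoxy group or from losing the two chlorines. A phenyl ring carrying a nitrile or trifluoromethyl group at this place could help separate the two.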